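Swapping acetyl for propyl on the ring nitrogen

A few compounds are considered here, and "the series" means these few. Any claim that something is new, unique, unknown or untested is made for them only; others in the source may bear on it.

Compound 3 `CC(=O)Nc1c(C)nc2c(OCc3ccccc3)cccn12` stands highest of the three measured compounds in a functional assay on the whole organism with Rattus norvegicus as the target, at a dose of 40 mg/kg by the intraperitoneal route (on this read-out higher numbers stand for more inhibition at the one dose given (going by the name of the read-out) and lower numbers for less inhibition), where compound 3 gives 93%. In this assay compound 2 `CCCCc1nc2c(OCc3ccccc3)cccn2c1N` gives 26%, and compound 1 `CC(C)c1nc2c(OCc3ccccc3)cccn2c1N` gives 0%. Within the data shown here, both of these carry a free amino group where compound 3 carries acetamido, but each also differs from compound 3 in a second place, so no single step joins them to it. Compound 4 `CCCNc1c(C)nc2c(OCc3ccccc3)cccn12` has not yet been measured; it differs from compound 3 in one place: propyl in place of acetyl on a nitrogen on an aromatic ring. Among the measured compounds shown here, the only one-place step measured so far is a number 26 percentage points higher from compound 1 to compound 2 (beyond the scatter), a change of a chain on an aromatic carbon, so it bears only loosely on a change at the nitrogen. What the numbers do show is that the two compounds without acetyl on that nitrogen, compound 1 and compound 2, lie far under compound 3. A drop is therefore expected for compound 4 in this assay, of about a number 53 percentage points lower from compound 3 to compound 4 (beyond the scatter). Compound 4 is estimated at 40%, within a range from 10% to 75%.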

Compound 4, a percentage reported as inhibition, in the whole organism at one dose (the size of the read-out at that dose, not a potency): 99%
Compound 4: middle estimate off by 59 percentage points, on the low side; the whole stated range lies below it.
By their numbers in this assay, from the lowest: compound 1; then compound 2; then compounds 3 and 4 (each within the scatter of the next).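

In this assay propyl in place of acetyl on a nitrogen on an aromatic ring gives a number 6 percentage points higher from compound 3 to compound 4 (within the scatter) and so leaves the read-out where it stood. At this position, then, the acetyl group with its carbonyl is not required for a high reading, something compound 1 and compound 2 could not show, as each differs from compound 3 in a second place as well. Nothing measured here accounts for why acetyl and propyl read alike on this nitrogen.

Going by these compounds, what a longer chain such as hexyl, or a chain ending in a carboxylic acid, would do on this nitrogen remains open. So does whether a free amine there, with the rest of compound 3 unchanged, would keep the reading as high.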